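Hydroxamate linker length on a shared sulfonyl furoxan core

The compounds below may be only part of what the source reports. "The series", "measured", "known", "first", "only" and "open" are said of these compounds alone.

The series keeps one core, shown by compound 1 `O=S(=O)(c1ccccc1)c1c(OCCCCCCO)no[n+]1[O-]`, and in a functional assay on ES2 cells (Homo sapiens) for inhibition, read by MTT assay, with a stated time of 48 h (a lower number here means a stronger inhibitor, a higher number a weaker inhibitor), compound 1 gives "not determined" (no result reported), so no number stands for it. Compound 2 `O=C(CCCOc1no[n+]([O-])c1S(=O)(=O)c1ccccc1)NO` carries a hydroxycarbamoyl group three bonds along a saturated chain from the oxygen on the aromatic ring, and in this assay compound 2 gives 3780 nM. Among the measured compounds shown here, compound 3 `O=C(CCCCCCOc1no[n+]([O-])c1S(=O)(=O)c1ccccc1)NO` extends that chain; in this assay compound 3 gives 7730 nM, the highest of the two numbers, with the one step of a 2.0-fold higher number from compound 2 to compound 3 (0.31 log units; beyond the scatter), a modest change beyond the scatter that accompanies the longer chain.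

Compound 4 `O=C(COCCOc1no[n+]([O-])c1S(=O)(=O)c1ccccc1)NO` is the next entry. Relative to compound 3 the change is (hydroxycarbamoyl)methoxy in place of 4-(hydroxycarbamoyl)butyl on a saturated chain carbon, two bonds along the chain from an oxygen on an aromatic ring. The chain between the aromatic oxygen and the hydroxycarbamoyl group thus becomes shorter again, and an oxygen enters it. For the measured compounds named here, the only step that bears on this is a 2.0-fold higher number from compound 2 to compound 3 (0.31 log units; beyond the scatter), where lengthening raised the number; the reverse direction is therefore expected here, with the oxygen in the chain an unknown without any measured precedent. Compound 4 is expected to sit near compound 2, a step of a 1.7-fold lower number from compound 3 to compound 4 (0.23 log units; within the scatter) in this assay. The estimate for compound 4 is 4500 nM, with a range from 1500 nM to 12000 nM.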

Compound 4, half-maximal inhibitory concentration: 8690 nM
Compound 4: the middle estimate sits 1.9-fold (0.29 log units) below what was measured; the measured number falls inside the stated range.
By their numbers in this assay, from the lowest: compound 2; then compounds 3 and 4 (each within the scatter of the next).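

In this assay, (hydroxycarbamoyl)methoxy in place of 4-(hydroxycarbamoyl)butyl gives a 1.1-fold higher number from compound 3 to compound 4 (0.05 log units; within the scatter) and so leaves compound 3 and compound 4 indistinguishable, although the entering group has 6 heavy atoms against 8 in the leaving group and 3 hydrogen-bond acceptors against 2. The same group in place of (hydroxycarbamoyl)methyl gives a 2.3-fold higher number from compound 2 to compound 4 (0.36 log units; beyond the scatter) as a modest step, so of the three measured compounds only compound 2 stands apart, and compound 4 goes against any reading in which a smaller group at this place brings a lower number. No data at hand bear on the origin of this result.

As far as these compounds go, it remains open whether an amine at the chain position of the new oxygen would track compound 4 or compound 2, and whether a chain longer than that of compound 3 would keep the number in the same region. A carboxylic acid in place of the hydroxycarbamoyl group would show how much of the activity depends on that group, a question compound 1 cannot settle without a number.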